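Cytotoxicity of Three Related Compounds on Vero Cells

The source may report more compounds than this note shows. Statements on the series, on what has been measured and on what is new or still open speak of the compounds shown alone.

compound 1 `CCOC(=O)c1cc(-c2cccc(OCc3cccc([N+](=O)[O-])c3)c2)on1`: > 128000 nM
compound 2 `CCOC(=O)c1cc(-c2cccc(OCc3cccc(OC)c3)c2)on1`: > 128000 nM
compound 3 `CCOC(=O)c1cc(-c2cccc(OCc3cccc(F)c3F)c2)on1`: not yet measured

In an ADME assay on Vero cells (Chlorocebus sabaeus) for cytotoxicity, with a stated time of 72 h (on this read-out higher numbers stand for weaker inhibition and lower numbers for stronger inhibition), compound 1 gives > 128000 nM, which is a limit of the assay and not a number. In this assay compound 2 gives > 128000 nM, again a limit rather than a measured number. The step that the two limits leave unreadable from compound 1 to compound 2 therefore cannot be sized. Compound 2 thus stands at the same limit as the other measured compound, (the limit of > 128000 nM in this assay, at which 2 of the 2 values shown sit). Compound 3 differs from compound 2 by 2,3-difluorophenyl in place of 3-methoxyphenyl on a saturated chain carbon bound to an oxygen on an aromatic ring. Going by the values given here, the only measured step bears on the same part of the molecule but is unreadable, so no direction can be drawn from it. With both measured compounds sitting at the limit of > 128000 nM in this assay, at which 2 of the 2 values shown sit, compound 3 is expected to sit there too, an expected step that the limit leaves unreadable from compound 2 to compound 3 that does not go beyond the scatter. The estimate for compound 3 in this assay is 200000 nM, ranging from 80000 nM to 1000000 nM.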

Compound 3, half-maximal inhibitory concentration: > 128000 nM
Compound 3 ended at the assay's limit; the forecaster's own chance of this, stated with the estimate: 85%; the middle value lies beyond the limit too.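

Going by these compounds alone, compound 1, compound 2 and compound 3 all end at a limit of the assay rather than at a number, so no step among them can be read: the limit of > 128000 nM in this assay, at which 3 of the 3 values shown sit. What the compounds shown leave open is whether these groups differ at all in this assay at concentrations beyond that limit.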